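This account rests on a few compounds, and the source may have more. Where it says the series, first, only, none or still open, it means among the compounds named here.

Working notes on the series. In a functional assay on MDA-MB-231 cells (Homo sapiens) for antiproliferative activity, read by MTT assay, with a stated time of 24 h (a lower number here means a stronger inhibitor, a higher number a weaker inhibitor), compound 1 (`CCCCc1oc2ccccc2c1C(=O)c1ccc(OCC(N)=O)cc1`) gives > 50000 nM, which is a limit and not a number. Compound 2 (`CCCCc1oc2ccccc2c1C(=O)c1ccc(OCC(=O)NC(C)C)cc1`) gives > 50000 nM, also a limit. Compound 2 therefore stands at the limit of > 50000 nM in this assay, at which 2 of the 2 values shown sit. Among the compounds with values here, the only measured step is a step that the two limits leave unreadable from compound 1 to compound 2, so it offers no size to carry forward. Compound 3 (`CCCCNC(=O)COc1ccc(C(=O)c2c(CCCC)oc3ccccc23)cc1`) differs from compound 2 by butyl in place of isopropyl on an amide-type nitrogen. No step beyond the scatter can be expected on this evidence, and the expected step is a number no higher from compound 2 to compound 3 (the limit leaves the size open). Compound 3 is estimated at 50000 nM, with an expected range of 15000 nM to 100000 nM.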

Compound 3, half-maximal inhibitory concentration: 34500 nM
For compound 3 the middle estimate is 1.4-fold (0.16 log units) above the measured one; low and high end bracket the measured number.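

Within the data shown here, on the amide-type nitrogen, butyl gives the first number in this assay that is not a limit, with an at least 1.4-fold lower number from compound 2 to compound 3 (0.16 log units; that floor lies within the scatter) and an at least 1.4-fold lower number from compound 1 to compound 3 (0.16 log units; that floor lies within the scatter). On these data alone, compound 1 and compound 2 give only limits, so the true size of either step stays open, and the floors alone do not separate butyl from isopropyl or hydrogen. The other two values remain limits: the limit of > 50000 nM in this assay, at which 2 of the 3 values shown sit.

Still open, as far as these compounds go, is whether a longer chain such as hexyl, or a terminal amine or carboxylic acid on the butyl chain, would move the number beyond the scatter.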